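Acetyl replaces methoxy on the aryl ring of compound 3

The compounds below may be only part of what the source reports. "The series", "measured", "known", "first", "only" and "open" are said of these compounds alone.

In an assay on membranes from brain for displacement of a labelled ligand from Sigma non-opioid intracellular receptor 1 (Cavia porcellus), read by scintillation counting, with a stated time of 120 min (a lower number here means a stronger inhibitor, a higher number a weaker inhibitor), compound 1 `COC1Cc2cscc2C2(CCN(Cc3ccccc3)CC2)O1` gives 0.22 nM, compound 2 `COC1Cc2c(csc2-c2ccc(C)cc2)C2(CCN(Cc3ccccc3)CC2)O1` gives 2 nM, and compound 3 `COc1ccc(-c2scc3c2CC(OC)OC32CCN(Cc3ccccc3)CC2)cc1` gives 2.2 nM. Compound 3 therefore holds the highest of the three numbers, though its separation from compound 2 is within the scatter, while its separation from compound 1 is not: the step of a 10-fold higher number from compound 1 to compound 3 (1.00 log units; beyond the scatter) matches the step of a 9.1-fold higher number from compound 1 to compound 2 (0.96 log units; beyond the scatter), so attaching either aryl group to the core of compound 1 costs about the same in this assay.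

Compound 4 `COC1Cc2c(csc2-c2ccc(C(C)=O)cc2)C2(CCN(Cc3ccccc3)CC2)O1` is not yet measured. It differs from compound 3 in one place: acetyl in place of methoxy on an aromatic carbon. The measured step that bears most directly on this change is a 1.1-fold higher number from compound 2 to compound 3 (0.04 log units; within the scatter), which shows that swapping one small group for another on that aryl ring left the number essentially unchanged. For the measured compounds named here, no measured pair shows an acetyl group anywhere, so the data give no direct guide to it. On the strength of that one comparison, compound 4 is expected to stay near compound 3, with a step of a 1.1-fold higher number from compound 3 to compound 4 (0.06 log units; within the scatter) that is not expected to exceed the scatter. The estimate for compound 4 in this assay is 2.5 nM, with a range from 1 nM to 7 nM.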

Compound 4, inhibition constant: 1.6 nM
The estimate for compound 4 lay 1.6-fold (0.19 log units) above the measured number; measured number inside the range.
By their numbers in this assay, from the lowest: compound 1; then compounds 4, 2 and 3 (each within the scatter of the next).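

In this assay, the group at the far end of the aryl ring now runs through methyl, methoxy and acetyl, and both new comparisons at that place, a 1.4-fold lower number from compound 3 to compound 4 (0.14 log units; within the scatter) and a 1.3-fold lower number from compound 2 to compound 4 (0.10 log units; within the scatter), stay within the scatter, so a group carrying a carbonyl fits the same flat picture as the two smaller groups. The price of adding the aryl ring also now rests on three examples rather than two: a 7.3-fold higher number from compound 1 to compound 4 (0.86 log units; beyond the scatter) stands with a 9.1-fold higher number from compound 1 to compound 2 (0.96 log units; beyond the scatter) and a 10-fold higher number from compound 1 to compound 3 (1.00 log units; beyond the scatter), and none of the three compounds goes against this, so in these compounds the loss follows the aryl ring itself and not the group it carries. No measurement is available that would explain why these three compounds sit together or why the aryl ring costs what it does.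

On these data alone, whether an amine or a carboxylic acid at the same place on the aryl ring would leave the number where it is remains open. Also open, as far as these compounds go, is whether a methyl or a chlorine on the core of compound 1, in place of the whole aryl group, would bring the same loss.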